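Working notes: trifluoromethoxy in place of cyano on compound 2

This account rests on a few compounds, and the source may have more. Where it says the series, first, only, none or still open, it means among the compounds named here.

In a physicochemical assay for lipophilicity, read by HPLC, measured as chromatographic lipophilicity, at pH 7.4 (on this read-out lower numbers stand for lower lipophilicity and higher numbers for higher lipophilicity), compound 2 (`COc1cccc(NC(=O)c2nnn(Cc3ccc(C#N)cc3)c2N)c1`) stands highest of the three measured compounds, at 2.3 against compound 1 (`COc1cccc(NC(=O)c2nnn(CC3CCN(C(C)=O)CC3)c2N)c1`) at 1.2 and compound 3 (`COc1cccc(NC(=O)c2nnn(CC3CCNCC3)c2N)c1`) at 0.6 on the same scale. Compound 4 (`COc1cccc(NC(=O)c2nnn(Cc3ccc(OC(F)(F)F)cc3)c2N)c1`) is reached from compound 2 by one change, trifluoromethoxy in place of cyano on an aromatic carbon in words trifluoromethoxy in place of cyano on an aromatic carbon, para to a large group.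

Within the data shown here, no measured step covers this exchange. The closest evidence is indirect: a number 1.10 log units higher from compound 1 to compound 2 (beyond the scatter) and a number 1.70 log units lower from compound 2 to compound 3 (beyond the scatter) are both large and replace the whole group on the saturated chain carbon, while a number 0.60 log units lower from compound 1 to compound 3 (beyond the scatter) is modest and sits on the amine nitrogen. These steps show only that this assay responds beyond the scatter to changes outside the shared core. The direction therefore rests on the structural change alone, and an upward step of large size is expected. The expected step is a number 1.00 log units higher from compound 2 to compound 4 (beyond the scatter) in this estimate. The estimated value for compound 4 is 3.3 with an expected range of 2.8 to 3.8 in this assay.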

Compound 4, distribution coefficient: 3.6
Compound 4: the middle estimate sits 0.30 log units below what was measured, within the range that was stated.
By their numbers in this assay, from the lowest: compound 3; then compound 1; then compound 2; then compound 4.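

In this assay, the aromatic carbon para to a large group responds on its own: trifluoromethoxy in place of cyano gives a number 1.30 log units higher from compound 2 to compound 4 (beyond the scatter). Among these compounds, the earlier steps all changed the group on the saturated chain carbon or the substituent on the amine nitrogen, so this is the first single-place change read on the aromatic ring itself, with the shared core and the chain carbon left as they were. No measurement in hand accounts for the size or direction of this step.

With only cyano and trifluoromethoxy compared at this carbon, the separate parts played by the oxygen and the fluorine atoms remain unresolved; trifluoromethyl or methoxy there would divide them. As far as these compounds go, whether the same position also allows a downward step remains open, and an amine or a carboxylic acid on that carbon would address it.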